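The source may report more compounds than this note shows. Statements on the series, on what has been measured and on what is new or still open speak of the compounds shown alone.

Working notes on the cyclopentenone ester series.

Three esters on the shared core have been measured. Compound 1, `CC/C=C\CC1C(=O)C=CC1CC(=O)OC`, a methyl ester, gives 19000 nM in a functional assay on RAW264.7 cells (Mus musculus) for inhibition, read by ELISA, with a stated time of 24 h; on this read-out higher numbers stand for an effect only at larger amounts of compound and lower numbers for an effect already at smaller amounts. Compound 2, `CC/C=C\C[C@H]1C(=O)C=C[C@H]1CC(=O)Oc1ccccc1`, carries a phenyl ester and in this assay compound 2 gives 33000 nM. Compound 3, `CC/C=C\C[C@H]1C(=O)C=C[C@H]1CC(=O)OCCOCCOCCOC`, with a longer ether-chain ester, gives 35000 nM in this assay. The number for compound 2 lies between those of compound 1 and compound 3, and both gaps fall within the usual scatter of repeated measurements, so the three esters read as one group of like numbers.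

Compound 4, `CC/C=C\C[C@H]1C(=O)C=C[C@H]1CC(=O)OC(C)C`, has not been measured. It differs from compound 2 in one place: isopropyl in place of phenyl on an oxygen next to a carbonyl group. Across the three measured esters the group on the ester oxygen has made no difference beyond the scatter, so for this assay no step beyond the scatter is expected from this change either. The step from compound 2 to compound 4 is therefore estimated at a 1.2-fold lower number from compound 2 to compound 4 (0.09 log units; within the scatter). For compound 4 the expected value in this assay is 27000 nM, with a range from 11000 nM to 65000 nM.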

Compound 4, half-maximal effective concentration: 20000 nM
Compound 4: middle estimate off by 1.4-fold (0.13 log units), on the high side; the measured number falls inside the stated range.
By their numbers in this assay, from the lowest: compounds 1, 4, 2 and 3 (each within the scatter of the next).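

This gives the series its first step between two compounds that differ in one place: in this assay, isopropyl in place of phenyl on an oxygen next to a carbonyl group gives a 1.7-fold lower number from compound 2 to compound 4 (0.22 log units; within the scatter). At this position, then, the six-membered aromatic ring can be exchanged for a group with no ring and fewer heavy atoms without the number leaving the scatter. No measurement on hand accounts for this result.

Still open, going by these compounds, is whether any change at this position can move the number beyond the scatter, since this one step does not test that for other groups. A carboxylic acid or an amide in place of the ester would show whether the ester itself matters for the number, which swapping one ester group for another cannot show.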